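The compounds below may be only part of what the source reports. "The series", "measured", "known", "first", "only" and "open" are said of these compounds alone.

- In an ADME assay on L02 cells (Homo sapiens) for cytotoxicity, read by MTT assay, with a stated time of 24 h (on this read-out lower numbers stand for stronger inhibition and higher numbers for weaker inhibition), compound 1 `COc1cc(/C=C/c2ccc(OCc3ccc(C(F)(F)F)cc3)cc2)c(-c2cnn[nH]2)c(OC)c1` gives > 100000 nM as a limit
- In this assay compound 2 `C=CCCCOc1ccc(/C=C/c2cc(OC)cc(OC)c2-c2cnn[nH]2)cc1` gives > 100000 nM as a limit

Compound 2 thus stands at a limit without a number, and the limit of > 100000 nM in this assay, at which 2 of the 2 values shown sit, is the whole record so far. Compound 3 `COCCOc1ccc(/C=C/c2cc(OC)cc(OC)c2-c2cnn[nH]2)cc1` carries methoxy in place of allyl on a saturated chain carbon, two bonds along the chain from an oxygen on an aromatic ring. Within the data shown here, the only measured step is a step that the two limits leave unreadable from compound 1 to compound 2 and offers no size to carry over. No step beyond the scatter is therefore expected in this assay in either direction. The expected step is a number no higher from compound 2 to compound 3 (the limit leaves the size open) on this estimate. For compound 3 the estimated value is 100000 nM with an expected range from 60000 nM to 200000 nM as the working figures.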

Compound 3, half-maximal inhibitory concentration: 94500 nM
Compound 3: middle estimate off by 1.1-fold (0.02 log units), on the high side, within the range that was stated.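

In this assay, among these compounds, methoxy on a saturated chain carbon, two bonds along the chain from an oxygen on an aromatic ring, gives the only reading here that is a number rather than a limit. The change from allyl gives an at least 1.0-fold lower number from compound 2 to compound 3 (0.02 log units; that floor lies within the scatter), and the change from 4-(trifluoromethyl)phenyl gives an at least 1.0-fold lower number from compound 1 to compound 3 (0.02 log units; that floor lies within the scatter). Neither replacement therefore shows a real change, and most of the record still sits at one limit: the limit of > 100000 nM in this assay, at which 2 of the 3 values shown sit.

On these data alone, the true size of both steps remains open. Also open, as far as these compounds go, is how an amine or a carboxylic acid at this position would read in this assay.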